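This account rests on a few compounds, and the source may have more. Where it says the series, first, only, none or still open, it means among the compounds named here.

All compounds here share a urea that joins a piperazine to an aromatic amine, and all were tested in an assay on HEK293 cells for inhibition of transient receptor potential cation channel subfamily V member 1 (Homo sapiens), read by FLIPR; on this read-out lower numbers stand for stronger inhibition and higher numbers for weaker inhibition. Compound 1 (`O=C(Nc1nc2ccc(F)cc2s1)N1CCN(c2ccc(Cl)nn2)CC1`) gives only a limit in this assay, > 10000 nM. Compound 2 (`Cc1cc(N2CCN(C(=O)Nc3ccc(C(C)C)cc3)CC2)nnc1Cl`) likewise sits at the limit, > 10000 nM. Compound 3 (`O=C(Nc1ccc(C(F)(F)F)cc1)N1CCN(c2ccc(-c3ccccc3)nn2)CC1`) also reaches only the limit, > 10000 nM. Among the compounds with values here, every value in this small set is thus a limit, as summarised by the limit of > 10000 nM in this assay, at which 3 of the 3 values shown sit, and no measured step between two compounds exists from which the size of a single structural change could be read.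

Compound 4 (`Cc1ccnnc1N1CCN(C(=O)Nc2nc3ccc(F)cc3s2)CC1`) has not yet been measured. It differs from compound 1 in one place, (4-methylpyridazin-3-yl in place of 6-chloropyridazin-3-yl on an amine nitrogen in a ring), that is, 4-methylpyridazin-3-yl in place of 6-chloropyridazin-3-yl on an amine nitrogen in a ring. Within the data shown here, with no measured step to lean on, the expectation can rest only on the three limits, which show weak inhibition for all three measured compounds. The step expected in this assay is a step that the limit leaves unreadable from compound 1 to compound 4, which amounts to none beyond the scatter. For compound 4 the estimate is therefore 15000 nM, with a range from 3000 nM to 60000 nM, and most likely this assay will again report only a limit for compound 4.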

Compound 4, half-maximal inhibitory concentration: 6170 nM
Compound 4: middle estimate off by 2.4-fold (0.39 log units), on the high side, and the stated range covers the measured number.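

Compound 4 is the only compound shown that gives a number rather than a limit in this assay (6170 nM), so inhibition in this series can come within the measurable range. Placing 4-methylpyridazin-3-yl in place of 6-chloropyridazin-3-yl on the amine nitrogen in the ring gives an at least 1.6-fold lower number from compound 1 to compound 4 (0.20 log units; that floor lies within the scatter), and a real change at this position therefore cannot be claimed, even though the true step may be larger. Only this floor can be read because compound 1 stands at the limit of the assay, not at a measured value: the limit of > 10000 nM in this assay, at which 3 of the 4 values shown sit.

The compounds shown leave open whether the loss of the chlorine, the gain of the methyl or the new place of the substituent on the pyridazine ring matters, as this single swap changes all three at once. A plain pyridazin-3-yl group, or one with an amine or a methoxy group in place of the methyl, could help to separate these effects, and the same swap on other aromatic amines of the urea would show whether any gain carries over.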